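A few compounds are considered here, and "the series" means these few. Any claim that something is new, unique, unknown or untested is made for them only; others in the source may bear on it.

In a functional assay on P388 cells (Mus musculus) for cytotoxicity (a lower number here means a stronger inhibitor, a higher number a weaker inhibitor), compound 1 `COc1ccc(Cc2cn(C3CC3)c3c(F)c(-c4cc(C)nc(C)c4)c(F)cc3c2=O)cc1` gives 21000 nM, while compound 2 `Cc1cc(-c2c(F)cc3c(=O)c(Cc4ccccc4N)cn(C4CC4)c3c2F)cc(C)n1` gives 2100 nM, the lower of the two numbers. Compound 3 `Cc1cc(-c2c(F)cc3c(=O)c(Cc4ccc(O)cc4)cn(C4CC4)c3c2F)cc(C)n1` differs from compound 2 as follows: 4-hydroxyphenyl in place of 2-aminophenyl on a saturated chain carbon bound to an aromatic carbon, with 4-hydroxyphenyl in place of 2-aminophenyl on a saturated chain carbon bound to an aromatic carbon. Among the compounds with values here, the group that leaves is the one that entered in the only measured step, a 10-fold lower number from compound 1 to compound 2 (1.00 log units; beyond the scatter), so part of that step is expected to be given back. The expected change, a moderately higher number, is a 2.9-fold higher number from compound 2 to compound 3 (0.46 log units; beyond the scatter). Compound 3 is estimated at 6000 nM, within a range of 1800 nM to 20000 nM.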

Compound 3, half-maximal inhibitory concentration: 1500 nM
Compound 3: middle estimate off by 4.0-fold (0.60 log units), on the high side; measured number outside the range, below it.
By their numbers in this assay, from the lowest: compounds 3 and 2 (each within the scatter of the next); then compound 1.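

In this assay, exchanging 2-aminophenyl for 4-hydroxyphenyl on the saturated chain carbon gives a 1.4-fold lower number from compound 2 to compound 3 (0.15 log units; within the scatter), so this position tolerates the exchange and the earlier gain is not tied to 2-aminophenyl. Hydrogen in place of methyl on the oxygen gives a 14-fold lower number from compound 1 to compound 3 (1.15 log units; beyond the scatter), a step as clear as the one seen with 2-aminophenyl. No evidence on the cause of either step is at hand. The compounds shown leave open how an unsubstituted phenyl, 4-aminophenyl or 2-hydroxyphenyl would compare here. They also leave open whether a carboxylic acid on this ring would hold the number.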